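Anilide variation on the shared core: compound 4

The source may hold more compounds than are shown below. What is called first, only, known or untested is meant among the compounds shown, and "the series" means these compounds.

Compound 1 `CN(C)C(=O)c1cc2cnc(Nc3ccc(NC(=O)C4(C(=O)Nc5cccc(O)c5)CC4)cc3)nc2n1C1CCCC1` is assessed in a functional assay on OVCAR-5 cells (Homo sapiens) for inhibition, read by CCK-8 assay, with a stated time of 72 h, tested at 10 uM (on this read-out higher numbers stand for more inhibition of growth at the one concentration tested and lower numbers for less inhibition of growth), where compound 1 gives 86%, the second highest of the three numbers measured. Compound 3 `CN(C)C(=O)c1cc2cnc(Nc3ccc(NC(=O)C4(C(=O)Nc5ccc(Br)cc5)CC4)cc3)nc2n1C1CCCC1` is nearest: in this assay compound 3 gives 87.8%, and the step of a number 1.8 percentage points higher from compound 1 to compound 3 (within the scatter) lies within the scatter. Compound 2 `CN(C)C(=O)c1cc2cnc(Nc3ccc(NC(=O)C4(C(=O)Nc5ccc(F)cc5)CC4)cc3F)nc2n1C1CCCC1` stands furthest from compound 1; in this assay compound 2 gives 33%. Going by the values given here, compound 2 differs from compound 1 in more than one place, so the two values show only that compound 2 is well lower.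

Compound 4 `Cc1ccc(NC(=O)C2(C(=O)Nc3ccc(Nc4ncc5cc(C(=O)N(C)C)n(C6CCCC6)c5n4)cc3)CC2)cc1` is not yet measured. It differs from compound 1 in one place: 4-methylphenyl in place of 3-hydroxyphenyl on an amide-type nitrogen. Among the compounds with values here, the only measured step bearing on this change is the exchange on the same amide-type nitrogen, a number 1.8 percentage points higher from compound 1 to compound 3 (within the scatter), which moved nothing beyond the scatter; no other compound varies this group alone. On that basis the step expected in this assay is a number 2 percentage points lower from compound 1 to compound 4 (within the scatter), none beyond the scatter. Compound 4 is therefore estimated at 84%, with a range from 70% to 93%.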

Compound 4, percent growth inhibition at one concentration: 80.6%
Beside the measured number, compound 4's estimate is 3.4 percentage points above it, within the range that was stated.
By their numbers in this assay, from the lowest: compound 2; then compounds 4, 1 and 3 (each within the scatter of the next).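

In this assay, the amide-type nitrogen accepts a third aryl group with no step beyond the scatter: the exchange of 3-hydroxyphenyl for 4-methylphenyl is a number 5.4 percentage points lower from compound 1 to compound 4 (within the scatter), and methyl in place of bromo on an aromatic carbon is a number 7.2 percentage points lower from compound 3 to compound 4 (within the scatter). The hydrogen-bond donor and acceptor counted on 3-hydroxyphenyl are therefore not needed at this position for growth inhibition within the scatter of compound 1 at the one concentration tested. Nothing available gives a reason for these small steps.

Still open, from the compounds shown here alone, is whether this position also accepts an aryl ring bearing an amine or a carboxylic acid, or a longer alkyl chain in place of the ring. Compound 2 differs from compounds 1, 3 and 4 in more than one place, so its low number cannot be assigned to a single change.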